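A few compounds are considered here, and "the series" means these few. Any claim that something is new, unique, unknown or untested is made for them only; others in the source may bear on it.

Measured in a functional assay on HOS cells (Homo sapiens) for antiproliferative activity; on this read-out lower numbers stand for stronger inhibition and higher numbers for weaker inhibition:
Compound 1 `Nc1n[nH]c(N)c1/N=N/c1ccccc1[N+](=O)[O-]`: > 100000 nM (a limit)
Compound 2 `Nc1n[nH]c(N)c1/N=N/c1ccccc1O`: > 100000 nM (a limit)

Compound 2 has no number in this assay, only the limit > 100000 nM. Compound 3 `Nc1n[nH]c(N)c1/N=N/c1ccccc1CO` departs from it in one group: hydroxymethyl in place of hydroxy on an aromatic carbon.

Among the measured compounds shown here, the one measured step, hydroxy in place of nitro on an aromatic carbon, is a step that the two limits leave unreadable from compound 1 to compound 2, so it offers no size to carry over. The nitro and hydroxy compounds both stand at the limit of > 100000 nM in this assay, at which 2 of the 2 values shown sit, and neither group has brought a number into range. For the measured compounds named here, nothing measured so far points to a gain or a loss from the new group, so no step beyond the scatter is expected in this assay and no direction can be given. Another limit is the likeliest report for compound 3. The estimated step is a number no higher from compound 2 to compound 3 (the limit leaves the size open). For compound 3 the estimate is 100000 nM, with an expected range from 30000 nM to 200000 nM.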

Compound 3, half-maximal inhibitory concentration: > 100000 nM
Compound 3 ended at the assay's limit (the forecaster's own chance of this, stated with the estimate: 80%); the middle value lies on the limit itself.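

Compound 3 joins compound 1 and compound 2 at a limit in this assay, so no new step can be read among the three: the limit of > 100000 nM in this assay, at which 3 of the 3 values shown sit.

The compounds shown leave open how nitro, hydroxy and hydroxymethyl compare with one another on the shared core, and which change to that core would bring a number into range.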